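Methyl for hydrogen on compound 1: expectation for compound 3

The compounds below may be only part of what the source reports. "The series", "measured", "known", "first", "only" and "open" are said of these compounds alone.

Measured so far:
Compound 1 `COc1ccccc1NC(=O)CN1CCN(S(=O)(=O)N2CCC(C)CC2)CC1` — > 10000 nM
Compound 2 `CCCC1CCN(C(=O)N2CCN(S(=O)(=O)N3CCN(CC(=O)Nc4cc(Cl)ccc4OC)CC3)CC2)CC1` — > 10000 nM

In an assay on HEK293 cells for inhibition of potassium channel subfamily T member 1 (Homo sapiens), read by thallium flux (on this read-out lower numbers stand for stronger inhibition and higher numbers for weaker inhibition), compound 1 gives > 10000 nM, which is a limit of the assay and not a number. Compound 2 in this assay gives > 10000 nM, also a limit. Within the data shown here, both values sit at the limit of > 10000 nM in this assay, at which 2 of the 2 values shown sit, so compound 1 stands only on a limit, and the one further value shown is likewise a limit. Among the measured compounds shown here, no step between measured compounds that differ in one place is available.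

Compound 3 `COc1ccc(C)cc1NC(=O)CN1CCN(S(=O)(=O)N2CCC(C)CC2)CC1` differs from compound 1 by methyl in place of hydrogen on an aromatic carbon. With nothing measured but two limits, the expected step that the limit leaves unreadable from compound 1 to compound 3 in this assay is none beyond the usual scatter. Compound 3 is therefore estimated at 20000 nM in this assay, with a range from 5000 nM to 80000 nM, and is expected most likely to be reported again only as a limit.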

Compound 3, half-maximal inhibitory concentration: > 10000 nM
Compound 3: only a limit was reported; the forecaster's own chance of this, stated with the estimate: 80%; the middle value lies beyond the limit too.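

Compound 1 and compound 3 stand only on limits in this assay, so no step can be read for methyl in place of hydrogen on the aromatic carbon: the limit of > 10000 nM in this assay, at which 3 of the 3 values shown sit.

The compounds shown leave open whether any of them inhibits measurably in this assay, and what size the methyl change has on the core of compound 1.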